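Methoxy for Fluoro: Expected Potency of Compound 3

A few compounds are considered here, and "the series" means these few. Any claim that something is new, unique, unknown or untested is made for them only; others in the source may bear on it.

Compound 1 `COc1ccc2nc(NC(=O)c3cn(-c4ccccc4)nc3-c3ccc(F)cc3)sc2c1` reaches only the limit of > 50000 nM in a functional assay on U-87MG ATCC cells for cytotoxicity against U-87 MG (Homo sapiens), read by MTT assay, with a stated time of 72 h; on this read-out higher numbers stand for weaker inhibition and lower numbers for stronger inhibition. For the measured compounds named here, compound 2 `COc1ccc(-c2nn(-c3ccccc3)cc2C(=O)Nc2nc3ccc(F)cc3s2)cc1` gives 8990 nM in this assay, the only measured number here, the other value being (the limit of > 50000 nM in this assay, at which 1 of the 2 values shown sits). Compound 3 `COc1ccc(-c2nn(-c3ccccc3)cc2C(=O)Nc2nc3ccc(OC)cc3s2)cc1` differs from compound 2 by methoxy in place of fluoro on an aromatic carbon. Going by the values given here, no measured pair shows this change, so its effect is uncertain. A modest weakening is expected, a step of a 1.7-fold higher number from compound 2 to compound 3 (0.22 log units; within the scatter). Compound 3 is therefore estimated at 15000 nM, with a range from 5000 nM to 50000 nM.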

Compound 3, half-maximal inhibitory concentration: 5890 nM
Estimate against measurement, compound 3: 2.5-fold (0.41 log units) above, within the range that was stated.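

On 6-fluoro-1,3-benzothiazol-2-yl to 6-methoxy-1,3-benzothiazol-2-yl, the change gives a 1.5-fold lower number from compound 2 to compound 3 (0.18 log units; within the scatter), so this position accepts either group without a clear difference. The same swap elsewhere in the molecule, with the 6-methoxy-1,3-benzothiazol-2-yl group kept, gives an at least 8.4-fold lower number from compound 1 to compound 3 (0.92 log units; beyond the scatter), so the place of the methoxy matters more than its presence here. Compound 1 stands at a limit, not a number: the limit of > 50000 nM in this assay, at which 1 of the 3 values shown sits.

As far as these compounds go, whether an amine or a carboxylic acid at this position would keep the activity remains open. So does the effect of a longer chain there.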